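A few compounds are considered here, and "the series" means these few. Any claim that something is new, unique, unknown or untested is made for them only; others in the source may bear on it.

Working notes on the series. Compound 1 `O=C(O)c1ccccc1-c1ccc(CCc2ncc(Cc3ccccc3Cl)[nH]2)cc1`, compound 2 `Cc1cccc(Cc2cnc(CCc3ccc(-c4ccccc4C(=O)O)cc3)[nH]2)c1` and compound 3 `O=C(O)c1ccccc1-c1ccc(CCc2ncc(CCC3CCCCC3)[nH]2)cc1` share one core and differ only in the group on a saturated chain carbon bound to an aromatic carbon. In an in vitro functional assay on cells for agonist activity at Bombesin receptor subtype-3 (Homo sapiens), read by luminescence and calcium flux (on this read-out lower numbers stand for an effect already at smaller amounts and higher numbers for an effect only at larger amounts of compound), compound 1 gives 292 nM. Compound 2 gives 4310 nM. Compound 3 gives 642 nM, which places compound 3 second highest of the three numbers, nearest to compound 1 and furthest from compound 2. The measured steps at this position read a 2.2-fold higher number from compound 1 to compound 3 (0.34 log units; beyond the scatter) and a 6.7-fold lower number from compound 2 to compound 3 (0.83 log units; beyond the scatter), and between the two aromatic groups a 15-fold higher number from compound 1 to compound 2 (1.17 log units; beyond the scatter). Compound 4 `O=C(O)c1ccccc1-c1ccc(CCc2ncc(Cc3cccc(F)c3F)[nH]2)cc1` is not yet measured. The change from compound 3 to compound 4 is 2,3-difluorophenyl in place of cyclohexylmethyl on a saturated chain carbon bound to an aromatic carbon. Both steps out of an aromatic group into cyclohexylmethyl bear on it: compound 1 to compound 3 was modest in the upward direction, compound 2 to compound 3 modest in the downward direction, so the aromatic groups bracket compound 3 on both sides. The expectation for compound 4 is therefore a step of modest size, more likely downward than upward, given that compound 1 with its 2-chlorophenyl gave 292 nM. The estimated step is a 1.6-fold lower number from compound 3 to compound 4 (0.21 log units; within the scatter). For compound 4 the estimate is 400 nM, with a range from 120 nM to 1500 nM.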

Compound 4, half-maximal effective concentration: 87 nM
For compound 4 the middle estimate is 4.6-fold (0.66 log units) above the measured one, outside the stated range (below it).
By their numbers in this assay, from the lowest: compound 4; then compound 1; then compound 3; then compound 2.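

In this assay the change out of cyclohexylmethyl reads a 7.4-fold lower number from compound 3 to compound 4 (0.87 log units; beyond the scatter) and places 2,3-difluorophenyl at the low end of the series, so an aromatic group at this position can now be seen to lie well below cyclohexylmethyl as well as above it. The choice of group on the aromatic ring therefore matters more here than the presence of the ring itself: the widest span in the series is a 50-fold lower number from compound 2 to compound 4 (1.69 log units; beyond the scatter) and separates two aromatic groups. The 2-chlorophenyl group does not mark the low end either, since the comparison of the two halogen-bearing groups gives a 3.4-fold lower number from compound 1 to compound 4 (0.53 log units; beyond the scatter) and both lie below cyclohexylmethyl, whereas 3-methylphenyl goes against that grouping by lying above it.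

The compounds shown leave open whether a single fluorine would account for the low number, as a 2-fluorophenyl or a 3-fluorophenyl group would tell, and whether 2-methylphenyl or 3-chlorophenyl would separate the kind of group on the ring from where it sits. Nothing available here gives a measured reason for any of these differences.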